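Aryl amide swap on a macrocyclic caspase-8 inhibitor

The compounds below may be only part of what the source reports. "The series", "measured", "known", "first", "only" and "open" are said of these compounds alone.

Measured compounds:
compound 1 `O=C1C[C@H](NC(=O)[C@@H]2COC[C@@H]3C/C=C\C[C@H](NC(=O)c4ccc(C(F)(F)F)cc4)C(=O)N32)C(O)O1` — 6450 nM
compound 2 `O=C1C[C@H](NC(=O)[C@@H]2COC[C@@H]3CCCC[C@H](NC(=O)c4cc5ccccc5s4)C(=O)N32)C(O)O1` — 429 nM

Of the compounds shown here, two have been measured in an assay on isolated protein for inhibition of Caspase-8 (Homo sapiens); on this read-out higher numbers stand for weaker inhibition and lower numbers for stronger inhibition. Compound 1 gives 6450 nM, the highest of the two numbers. Compound 2 gives 429 nM, a lower number, and the gap between the two lies beyond the scatter; the two compounds differ in more than one place, so the gap is not tied to any single change.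

Compound 3 `O=C1C[C@H](NC(=O)[C@@H]2COC[C@@H]3C/C=C\C[C@H](NC(=O)c4cccc(Cl)c4)C(=O)N32)C(O)O1` has not yet been measured in this assay. It differs from compound 1 in one place: 3-chlorophenyl in place of 4-(trifluoromethyl)phenyl on a carbonyl carbon. For the measured compounds named here, no measured pair shows this change alone, so its effect is not known from the data. The expected step from compound 1 to compound 3 is estimated as a 1.6-fold lower number from compound 1 to compound 3 (0.21 log units; within the scatter), a small move towards a lower number that may well fall within the scatter. Compound 3 is therefore expected to give about 4000 nM in this assay, in a range from 1500 nM to 12000 nM.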

Compound 3, half-maximal inhibitory concentration: 1550 nM
Estimate against measurement, compound 3: 2.6-fold (0.41 log units) above; measured number inside the range.
By their numbers in this assay, from the lowest: compound 2; then compound 3; then compound 1.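

In this assay, for the compounds shown here, the group on this carbonyl carbon can move the number by itself: with the shared core unchanged, 3-chlorophenyl in place of 4-(trifluoromethyl)phenyl gives a 4.2-fold lower number from compound 1 to compound 3 (0.62 log units; beyond the scatter) and is the first change at this position seen alone. The earlier gap between compound 1 and compound 2 could not be tied to any single change, whereas this step belongs to the aryl swap. Nothing in the available data explains the step.

Going by these compounds, whether a plain phenyl, a 4-chlorophenyl or a 3-methoxyphenyl on the same carbonyl carbon would give a number nearer that of compound 3 or that of compound 1 remains open. On these data alone, it is also open whether 3-chlorophenyl would bring a similar step on the core of compound 2.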